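The source may hold more compounds than are shown below. What is called first, only, known or untested is meant among the compounds shown, and "the series" means these compounds.

Of the compounds shown here, two sharing one core have been measured so far. In a physicochemical assay for solubility, using the shake flask method, in phosphate buffer, with a stated time of 24 h, at pH 7.4 (on this read-out lower numbers stand for lower solubility and higher numbers for higher solubility), compound 1 `Cn1ncc2c(=O)n(-c3ccccc3)c(COc3cccc(F)c3)nc21` gives 194000 nM and compound 2 `Cn1ncc2c(=O)n(-c3ccccc3)c(CCc3cccc(F)c3)nc21` gives 126000 nM, so compound 2 sits within the usual scatter of compound 1. Within the data shown here, only one measured step bears on what comes next: a 1.5-fold lower number from compound 1 to compound 2 (0.19 log units; within the scatter), with 3-fluorobenzyl in place of 3-fluorophenoxy on a saturated chain carbon bound to an aromatic carbon. Compound 3 `Cn1ncc2c(=O)n(-c3ccccc3)c(CNc3cccc(F)c3)nc21` differs from compound 2 in that same place: (3-fluorophenyl)amino in place of 3-fluorobenzyl on a saturated chain carbon bound to an aromatic carbon. Among the measured compounds shown here, no measured compound yet carries the (3-fluorophenyl)amino group, so this single step is a thin guide. Even so, it gives no reason to expect a real shift in either direction in this assay. The expected change is a 1.2-fold higher number from compound 2 to compound 3 (0.08 log units; within the scatter), no step beyond the scatter. The estimate for compound 3 is 150000 nM, with an expected range from 60000 nM to 350000 nM.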

Compound 3, solubility: 64000 nM
For compound 3 the middle estimate is 2.3-fold (0.37 log units) above the measured one, and the stated range covers the measured number.
By their numbers in this assay, from the lowest: compounds 3, 2 and 1 (each within the scatter of the next, the first and the last beyond it).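

In this assay, this place on the shared core now shows a step that clears the scatter: a 3.0-fold lower number from compound 1 to compound 3 (0.48 log units; beyond the scatter), as the (3-fluorophenyl)amino group of compound 3 takes over from the 3-fluorophenoxy group of compound 1. Set against 3-fluorobenzyl, which has 0 hydrogen-bond donors where (3-fluorophenyl)amino has 1, the same group gives a 2.0-fold lower number from compound 2 to compound 3 (0.29 log units; within the scatter), so it stands clearly apart from only one of the two earlier groups. Nothing measured here accounts for either step.

The compounds shown leave open whether the hydrogen on the amino nitrogen matters, which a methyl group on that nitrogen would test. They also leave open whether the fluorine matters, which a plain phenylamino group would test.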